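Two diaryl ketone pyrroles at the assay ceiling; pyridyl variant next

A few compounds are considered here, and "the series" means these few. Any claim that something is new, unique, unknown or untested is made for them only; others in the source may bear on it.

In an assay for inhibition of Polyunsaturated fatty acid lipoxygenase ALOX15 (Homo sapiens), with a stated time of 10 min (a higher number here means a weaker inhibitor, a lower number a stronger inhibitor), compound 1 `Nc1[nH]c(C(=O)c2ccccc2)c(-c2ccc(Cl)cc2Cl)c1C(=O)c1ccccc1` gives only a limit, > 100000 nM. Compound 2 `Nc1[nH]c(C(=O)c2ccccc2)c(-c2cccc(Cl)c2)c1C(=O)c1cccc(Cl)c1` likewise returns only a limit in this assay, > 100000 nM. Both values therefore sit at the limit of > 100000 nM in this assay, at which 2 of the 2 values shown sit; compound 2 stands at the ceiling, with no number to rank it. Compound 3 `Nc1[nH]c(C(=O)c2ccccc2)c(-c2ccncc2)c1C(=O)c1cccc(Cl)c1` differs from compound 2 by pyridin-4-yl in place of 3-chlorophenyl on an aromatic carbon. Going by the values given here, no measured step exists for this change; the expected step from compound 2 to compound 3 is a step that the limit leaves unreadable from compound 2 to compound 3, none beyond the scatter. Compound 3 is expected to give 150000 nM in this assay, between 40000 nM and 600000 nM, most likely again as a limit.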

Compound 3, half-maximal inhibitory concentration: > 100000 nM
Compound 3: only a limit was reported; the forecaster's own chance of this, stated with the estimate: 85%; the middle value is on the limit's open side.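

Compound 2 and compound 3 both give only limits, so no step between them can be read: the limit of > 100000 nM in this assay, at which 3 of the 3 values shown sit.

The compounds shown leave open how pyridin-4-yl and 3-chlorophenyl rank, and whether any change on the shared core gives a measurable inhibitory concentration.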